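This account rests on a few compounds, and the source may have more. Where it says the series, first, only, none or still open, it means among the compounds named here.

Among the compounds with values here, compound 2, `CSCC[C@H](NC(=O)CN(c1ncnc2c1ncn2C1CCCCO1)C1CC1)C(=O)OCc1ccccc1`, stands highest of the two numbers measured so far in a functional assay on the whole organism (Tail, strain ICR) with Mus musculus as the target, in the tail flick test, with a stated time of 60 min, at a dose of 25 umol/kg by the oral route (a higher number here means a stronger effect of the compound at the dose given, a lower number a weaker effect), where compound 2 gives 41%. Within the data shown here, its only neighbour, compound 1, `NC(=O)C[C@H](NC(=O)CN(c1ncnc2c1ncn2C1CCCCO1)C1CC1)C(=O)OCc1ccccc1`, gives 30.5% in this assay, and the step of a number 10.5 percentage points higher from compound 1 to compound 2 (beyond the scatter) separates the two. The new compound 3, `CC(C)[C@H](NC(=O)CN(c1ncnc2c1ncn2C1CCCCO1)C1CC1)C(=O)OCc1ccccc1`, differs from compound 2 by isopropyl in place of 2-(methylsulfanyl)ethyl on a saturated chain carbon bound to an amide-type nitrogen and a carbonyl carbon. Among the measured compounds shown here, the one measured step, from compound 1 to compound 2, exchanged the same side chain and moved the number by a modest amount, so an exchange of this side chain has not swung the result strongly in the data at hand. For the measured compounds named here, no measured compound carries the isopropyl group, so its effect is unknown; the step of a number 6 percentage points lower from compound 2 to compound 3 (within the scatter) is therefore expected to be small, with no firm direction. Compound 3 is estimated to give about 35% in this assay, within a range from 20% to 50%.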

Compound 3, a percentage reported as activity, at one dose (the size of the read-out at that dose, not a potency): 34.9%
The estimate for compound 3 lay 0.1 percentage points above the measured number; low and high end bracket the measured number.
By their numbers in this assay, from the lowest: compounds 1, 3 and 2 (each within the scatter of the next, the first and the last beyond it).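

Exchanging the side chain gives a number 6.1 percentage points lower from compound 2 to compound 3 (within the scatter) in this assay, and the exchange against the other earlier side chain gives a number 4.4 percentage points higher from compound 1 to compound 3 (within the scatter). Isopropyl, which has no sulfur and one heavy atom fewer than 2-(methylsulfanyl)ethyl, therefore cannot be told apart from either earlier group on this saturated chain carbon bound to an amide-type nitrogen and a carbonyl carbon, even though compound 1 and compound 2 differ from each other beyond the scatter. No measurement is available that would explain these small differences.

As far as these compounds go, whether an amine, a carboxylic acid or a longer carbon chain at this place would move the number further remains open. These read-outs also come from a single dose, so they show the size of the effect at that dose and say nothing about potency.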